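Cyclic amine in place of dipropylamino on the shared core

This account rests on a few compounds, and the source may have more. Where it says the series, first, only, none or still open, it means among the compounds named here.

Measured compounds:
compound 1 `CCCCNc1nc(C(F)(F)F)ccc1CNC(=O)C(C)c1ccc(NS(C)(=O)=O)c(F)c1` 293 nM
compound 2 `CC(C(=O)NCc1ccc(C(F)(F)F)nc1NCc1ccc(Cl)cc1)c1ccc(NS(C)(=O)=O)c(F)c1` 414 nM
compound 3 `CCCN(CCC)c1nc(C(F)(F)F)ccc1CNC(=O)C(C)c1ccc(NS(C)(=O)=O)c(F)c1` 14.7 nM

All three were tested in a functional assay on CHO-K1 cells for antagonist activity at transient receptor potential cation channel subfamily V member 1 (Homo sapiens), read by FLIPR; on this read-out higher numbers stand for weaker inhibition and lower numbers for stronger inhibition. Compound 3 gives the lowest number of the three: the step of a 20-fold lower number from compound 1 to compound 3 (1.30 log units; beyond the scatter) and the step of a 28-fold lower number from compound 2 to compound 3 (1.45 log units; beyond the scatter) are both large. In both of these steps dipropylamino stands in place of an amino group that still carries a hydrogen. Between compound 1 and compound 2 the step is a 1.4-fold higher number from compound 1 to compound 2 (0.15 log units; within the scatter).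

Compound 4 `CC(C(=O)NCc1ccc(C(F)(F)F)nc1N1CC=CCC1)c1ccc(NS(C)(=O)=O)c(F)c1` is the next step from compound 3: a group of 6 heavy atoms (5 carbon, 1 nitrogen; one six-membered non-aromatic ring with 1 hetero atom) in place of a group of 7 heavy atoms (6 carbon, 1 nitrogen; no ring), on an aromatic carbon. The entering group, like dipropylamino, has no hydrogen-bond donor and one hydrogen-bond acceptor, so the feature that set compound 3 apart from compound 1 and compound 2 is kept; what changes is that the two carbon chains are tied into a six-membered non-aromatic ring holding one double bond. Going by the values given here, no measured step tests a ring of this kind, so the expectation rests on the likeness to compound 3. In this assay the expected step of a 1.7-fold higher number from compound 3 to compound 4 (0.23 log units; within the scatter) is small, within the scatter or at most a modest move toward a higher number. Compound 4 is therefore estimated at 25 nM, with a likely range from 8 nM to 80 nM.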

Compound 4, half-maximal inhibitory concentration: 12.1 nM
Compound 4: the middle estimate sits 2.1-fold (0.32 log units) above what was measured; measured number inside the range.
By their numbers in this assay, from the lowest: compounds 4 and 3 (each within the scatter of the next); then compounds 1 and 2 (each within the scatter of the next).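

In this assay, tying the two carbon chains of dipropylamino into a six-membered non-aromatic ring with a double bond leaves the number within the scatter (a 1.2-fold lower number from compound 3 to compound 4 (0.08 log units; within the scatter)), so at this aromatic carbon next to the ring nitrogen an open pair of chains is not needed for a low number. The ring compound also keeps the large distance from the two amino groups that still carry a hydrogen (a 24-fold lower number from compound 1 to compound 4 (1.38 log units; beyond the scatter); a 34-fold lower number from compound 2 to compound 4 (1.53 log units; beyond the scatter)), and so, among these four compounds, both low numbers belong to groups with no hydrogen on the attached nitrogen, with no compound going against this. Nothing given here explains why these numbers fall as they do.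

The compounds shown leave open whether the double bond matters, a question that piperidine, the same ring without it, would address. Going by these compounds, how much room this position allows also remains open, as pyrrolidine with its smaller ring, morpholine with its ring oxygen and dibutylamino with its longer chains would each test a different limit.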